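Replacing the 4-hydroxyphenyl group of compound 3

This account rests on a few compounds, and the source may have more. Where it says the series, first, only, none or still open, it means among the compounds named here.

compound 1 `COc1cc(NC(C)CCCNC(=O)/C=C/c2ccccc2F)c2ncccc2c1`: 1.5 ug/mL
compound 2 `COc1cc(NC(C)CCCNC(=O)Nc2cccc(O)c2)c2ncccc2c1`: 38 ug/mL
compound 3 `COc1cc(NC(C)CCCNC(=O)Nc2ccc(O)cc2)c2ncccc2c1`: 14.8 ug/mL

These values come from an ADME assay on L6 cells (Rattus norvegicus) for cytotoxicity, read by resazurin assay, with a stated time of 70 h; on this read-out lower numbers stand for stronger inhibition and higher numbers for weaker inhibition. Compound 3, at 14.8 ug/mL, holds the middle place of the three numbers, lower than compound 2 and higher than compound 1.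

The next compound, compound 4 `COc1cc(NC(C)CCCNC(=O)Nc2cccc(Cl)c2)c2ncccc2c1`, carries 3-chlorophenyl in place of 4-hydroxyphenyl on an amide-type nitrogen. Exchanging 3-hydroxyphenyl for 4-hydroxyphenyl gave a 2.6-fold lower number from compound 2 to compound 3 (0.41 log units; beyond the scatter), a modest step. The larger exchanges at the carbonyl carbon gave a 9.9-fold higher number from compound 1 to compound 3 (0.99 log units; beyond the scatter) and a 25-fold higher number from compound 1 to compound 2 (1.40 log units; beyond the scatter). Compound 1, which has no hydroxyphenyl group, gives 1.5 ug/mL. Among the measured compounds shown here, no compound with a chlorophenyl group has been measured, so these steps guide only loosely. A modest step towards a lower number is therefore expected in this assay.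

This estimate means an expected 2.5-fold lower number from compound 3 to compound 4 (0.39 log units; beyond the scatter).

For compound 4 the expected value is 6 ug/mL, with an estimated range from 2 ug/mL to 18 ug/mL.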

Compound 4, half-maximal inhibitory concentration: 10 ug/mL
Compound 4: the middle estimate sits 1.7-fold (0.22 log units) below what was measured, within the range that was stated.
By their numbers in this assay, from the lowest: compound 1; then compounds 4 and 3 (each within the scatter of the next); then compound 2.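

In this assay, 3-chlorophenyl in place of 4-hydroxyphenyl on the amide-type nitrogen gave a 1.5-fold lower number from compound 3 to compound 4 (0.17 log units; within the scatter) and so does not separate the two compounds, even though the entering group has no hydrogen-bond donor or acceptor. Chloro in place of hydroxy on an aromatic carbon gave a 3.8-fold lower number from compound 2 to compound 4 (0.58 log units; beyond the scatter) and so, unlike the previous change, moved the number beyond the scatter. The (3-chlorophenyl)amino group in place of 2-(2-fluorophenyl)ethenyl on a carbonyl carbon gave a 6.7-fold higher number from compound 1 to compound 4 (0.82 log units; beyond the scatter) and thus leaves the chlorophenyl compound clearly apart from compound 1.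

Nothing shown gives a reason for these steps. On these data alone, what a 4-chlorophenyl group, or an amine in place of the chloro, would give on the same amide-type nitrogen remains open.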